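The source may hold more compounds than are shown below. What is called first, only, known or untested is meant among the compounds shown, and "the series" means these compounds.

Measured compounds:
Compound 1, `C=Cc1ccc(-c2cc(C)c3ncc(CSCCc4ccccc4)n3c2)cc1`, gives 20 ug/mL in an ADME assay on HEL cells (Homo sapiens) for cytotoxicity, with a stated time of 3 days; a higher number here means that more compound is tolerated, a lower number that less compound is tolerated.
Compound 2, `Cc1cc(-c2ccc3[nH]ccc3c2)cn2c(CSCCc3ccccc3)cnc12`, gives >= 20 ug/mL, which is a limit of the assay and not a number.
Compound 3, `Cc1cc(N2CCCC2=O)cn2c(CSCCc3ccccc3)cnc12`, gives > 100 ug/mL, which is also a limit rather than a number.

Compound 2 therefore stands only at a boundary: its true value is at or past the point where the measurement stopped (the limit of >= 20 ug/mL in this assay, at which 1 of the 3 values shown sits), so its exact number is open. Compound 4, `Cc1cc(-n2cccc2)cn2c(CSCCc3ccccc3)cnc12`, is the next compound to be measured. Its change from compound 2 is 1H-pyrrol-1-yl in place of 1H-indol-5-yl on an aromatic carbon.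

Going by the values given here, two measured steps touch this position, and both are bounded by limits. The step of a number no lower from compound 1 to compound 2 (the limit leaves the size open) cannot be sized, and neither can the step that the two limits leave unreadable from compound 2 to compound 3. The step of an at least 5.0-fold higher number from compound 1 to compound 3 (0.69 log units; beyond the scatter) is the only one with a readable size, and it shows that a 2-oxopyrrolidin-1-yl group at this position reached the upper boundary of the measurement (the limit of > 100 ug/mL in this assay, at which 1 of the 3 values shown sits). Pyrrol-1-yl, like that group, is attached through its nitrogen and is smaller than indolyl.

The step that the limit leaves unreadable from compound 2 to compound 4 is expected to be modest and upward, though the limits make this uncertain. Compound 4 is estimated at 50 ug/mL, within 20 ug/mL to 100 ug/mL.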

Compound 4, minimum cytotoxic concentration: >= 4 ug/mL
Compound 4: no number, only a limit; the forecaster's own chance of this, stated with the estimate: 50%; the middle value is on the limit's open side.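

In this assay compound 4 gives >= 4 ug/mL, which is a limit of the assay and not a number. The steps linking compound 4 with compound 1, compound 2 and compound 3 cannot be read. The compounds shown leave open how 1H-pyrrol-1-yl truly compares with the other groups at this aromatic carbon in how much compound is tolerated.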